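The compounds below may be only part of what the source reports. "The series", "measured", "known", "first", "only" and "open" are said of these compounds alone.

In a functional assay on MDA-MB-231 cells (Homo sapiens) for antiproliferative activity, read by MTT assay, with a stated time of 72 h (on this read-out higher numbers stand for weaker inhibition and lower numbers for stronger inhibition), compound 2 `CC1=CC[C@H]2[C@H](CC[C@]2(C)O)C(C)(C)[C@@H]1CC[C@H]1[C@]2(C)CC[C@H](OC(=O)c3ccc(Cl)cc3)C(C)(C)O[C@H]2CC[C@@]1(C)O` gives 10300 nM. Against compound 1 `CC1=CC[C@H]2[C@H](CC[C@]2(C)O)C(C)(C)[C@@H]1CC[C@H]1[C@]2(C)CC[C@H](OC(=O)c3ccc(C)cc3)C(C)(C)O[C@H]2CC[C@@]1(C)O`, which gives 33400 nM, the number of compound 2 is clearly lower. Compound 3 `CC1=CC[C@H]2[C@@H]1CC=C(C)[C@@H](CC[C@H]1[C@]3(C)CC[C@H](OC(=O)c4ccncc4)C(C)(C)O[C@H]3CC[C@@]1(C)O)C2(C)C` gives 19100 nM, which lies within the scatter of the number of compound 2. Compound 4 `CC1=CC[C@H]2[C@H](CC[C@]2(C)O)C(C)(C)[C@@H]1CC[C@H]1[C@]2(C)CC[C@H](OC(=O)c3ccc(C(F)(F)F)cc3)C(C)(C)O[C@H]2CC[C@@]1(C)O` keeps the structure of compound 2 except for one change, trifluoromethyl in place of chloro on an aromatic carbon, para to a large group. Going by the values given here, only one measured step bears on this place, a 3.2-fold lower number from compound 1 to compound 2 (0.51 log units; beyond the scatter), where chloro replaced methyl. That single modest step gives no firm direction for the new group, so no clear shift is expected. The estimate is a 1.2-fold higher number from compound 2 to compound 4 (0.07 log units; within the scatter), a step not expected to exceed the scatter. For compound 4 the expected value is 12000 nM, with an estimated range from 5000 nM to 28000 nM.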

Compound 4, half-maximal inhibitory concentration: 19500 nM
Estimate against measurement, compound 4: 1.6-fold (0.21 log units) below; measured number inside the range.
By their numbers in this assay, from the lowest: compounds 2, 3, 4 and 1 (each within the scatter of the next, the first and the last beyond it).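

The steps of a 1.9-fold higher number from compound 2 to compound 4 (0.28 log units; within the scatter) and a 1.7-fold lower number from compound 1 to compound 4 (0.23 log units; within the scatter) set compound 4 apart from neither compound 2 nor compound 1, although those two stand apart from each other. This place on the aromatic ring thus takes trifluoromethyl, with its four heavy atoms, without a step beyond the scatter from either chloro or methyl. As far as these compounds go, whether an amine, a hydroxyl group or a carboxylic acid at this place would give a step beyond the scatter stays open. Nothing available explains the numbers of these compounds.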